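The compounds below may be only part of what the source reports. "The series", "measured", "known", "first", "only" and "open" are said of these compounds alone.

For the measured compounds named here, compound 1 `Cc1nc2c(N)ncnc2n1[C@@H]1O[C@H](CN(C)CCC(N)=O)[C@@H](O)[C@H]1O` is one of two compounds measured in an assay on isolated protein for inhibition of S-adenosylmethionine decarboxylase proenzyme (Homo sapiens); a lower number here means a stronger inhibitor, a higher number a weaker inhibitor. In this assay compound 1 gives 400 nM, the higher of the two numbers. The other measured compound, compound 2 `CCc1nc2c(N)ncnc2n1[C@@H]1O[C@H](CN(C)CCCCON)[C@@H](O)[C@H]1O`, differs from compound 1 at more than one place, and in this assay compound 2 gives 15 nM; the gap between the two values lies beyond the scatter, so compound 2 is the stronger inhibitor of the pair.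

Compound 3 `Cc1nc2c(N)ncnc2n1[C@@H]1O[C@H](CN(C)CCCN)[C@@H](O)[C@H]1O` has not yet been measured. It is derived from compound 1 by a single change: aminomethyl in place of carbamoyl on a saturated chain carbon, two bonds along the chain from an amine nitrogen. Going by the values given here, no measured pair in this set shows this exact change on its own, so the size of the step can only be estimated. The expectation is a step from compound 1 to compound 3 of a 10-fold lower number from compound 1 to compound 3 (1.00 log units; beyond the scatter), toward stronger inhibition. On that basis compound 3 is estimated to give 40 nM in this assay, within a range from 10 nM to 160 nM.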

Compound 3, half-maximal inhibitory concentration: 70000 nM
Compound 3: the middle estimate sits 1800-fold (3.24 log units) below what was measured; the measured number lies above the stated range.
By their numbers in this assay, from the lowest: compound 2; then compound 1; then compound 3.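

Putting aminomethyl in place of carbamoyl on this saturated chain carbon, two bonds along the chain from an amine nitrogen, gives a 180-fold higher number from compound 1 to compound 3 (2.24 log units; beyond the scatter) in this assay and so a large loss of inhibition. This position is therefore far from indifferent: the swap removes only one heavy atom overall and leaves the counts of hydrogen-bond donors and acceptors unchanged, yet the number moves strongly toward weaker inhibition. Nothing measured here explains this loss.

For the compounds shown here, only this one pair shows the change, so it remains open whether other groups at this place can keep inhibition. A carboxylic acid, a hydroxymethyl or a longer chain ending in an amine would show whether the loss follows the incoming amine or the missing carbonyl.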